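Pyridyl-acrylamide series: from amino-acid amide to ethyl ester

The source may hold more compounds than are shown below. What is called first, only, known or untested is meant among the compounds shown, and "the series" means these compounds.

Measured compounds:
- compound 1 `CC(C)[C@@H](NC(=O)/C=C/c1ccncc1-c1ccc2ccccc2c1)C(=O)O`: 77%
- compound 2 `CNC(=O)/C=C/c1ccncc1-c1ccc2[nH]ccc2c1`: 100%
- compound 3 `O=C(O)/C=C/c1ccncc1-c1ccc2[nH]ccc2c1`: 102%

In an assay on a protein complex for inhibition of CDK8/Cyclin C (Homo sapiens), with a stated time of 1 h, tested at 10 uM (on this read-out lower numbers stand for less inhibition and higher numbers for more inhibition at the one concentration tested (going by the name of the read-out)), compound 1 gives 77%, the lowest of the three numbers; compound 2 and compound 3 both stand beyond the scatter above it. Among the compounds with values here, the only single-point step among the measured compounds is a number 2 percentage points higher from compound 2 to compound 3 (within the scatter), a change on the carbonyl carbon that leaves the number unchanged within the scatter, though on a core different from that of compound 1.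

Compound 4 `CCOC(=O)/C=C/c1ccncc1-c1ccc2ccccc2c1` is not yet measured. It differs from compound 1 as follows: ethoxy in place of (1-carboxy-2-methylpropyl)amino on a carbonyl carbon. Within the data shown here, this is again a change on the carbonyl carbon, and the one comparable step, from compound 2 to compound 3, was within the scatter. Among the measured compounds shown here, no measured pair shows an ethoxy group or the loss of the (1-carboxy-2-methylpropyl)amino group on this core, so the expectation rests on compound 1 alone. Compound 4 is therefore expected to stay close to compound 1, with a step of about a number 1 percentage points higher from compound 1 to compound 4 (within the scatter), not beyond the scatter in either direction. The estimate for compound 4 in this assay is 78%, with a range from 55% to 95%.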

Compound 4, a percentage reported as inhibition, at one concentration (the size of the read-out at that concentration, not a potency): 102%
The estimate for compound 4 lay 24 percentage points below the measured number; the whole stated range lies below it.
By their numbers in this assay, from the lowest: compound 1; then compounds 2, 3 and 4 (each within the scatter of the next).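

In this assay, the carbonyl carbon of the core of compound 1 proves sensitive to this change: ethoxy in place of (1-carboxy-2-methylpropyl)amino gives a number 25 percentage points higher from compound 1 to compound 4 (beyond the scatter), whereas the earlier change at a carbonyl carbon, on a different core, gave a number 2 percentage points higher from compound 2 to compound 3 (within the scatter). A change at this carbon therefore need not remain within the scatter, and the amino-acid group is not needed to reach the number for compound 4. The change removes 8 heavy atoms, 2 hydrogen-bond donors and the defined stereocentre together and adds 3 heavy atoms, and no measurement bears on the reason for the step.

It remains open which part of the departing group accounts for the step: the carboxylic acid, the side chain or the amide hydrogen. Plain amino or propoxy on the same carbonyl carbon would test whether the step depends on the amide link or on the size of the group.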